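The compounds below may be only part of what the source reports. "The series", "measured", "known", "first", "only" and "open" are said of these compounds alone.

Compound 1 `Fc1cc(C(F)(F)F)ccc1-c1ccc(Cn2nnc3ccccc32)cc1` and compound 2 `FC(F)(F)c1ccc(-c2ccc(Cn3nnc4ccccc43)cc2)c(Cl)c1` share a core whose difference from the core of compound 3 `Fc1ccc(Cn2nnc3c(Br)cccc32)cc1` is not broken down here. In a functional assay on cells for positive allosteric modulation of metabotropic glutamate receptor 2 (Homo sapiens), read by fluorescence and calcium flux, with a stated time of 30 min (a higher number here means that more compound is needed for the effect, a lower number that less compound is needed), compound 1 gives 29 nM, and in this assay compound 2 gives 37 nM. The change between them, (chloro in place of fluoro on an aromatic carbon), made a 1.3-fold higher number from compound 1 to compound 2 (0.11 log units; within the scatter). In this assay compound 3 gives 15 nM, which against compound 1 lies within the scatter and against compound 2 lies beyond it.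

Compound 4 `Clc1ccc(Cn2nnc3c(Br)cccc32)cc1` is not yet measured in this assay. It arises from compound 3 by chloro in place of fluoro on an aromatic carbon, the same kind of change as that from compound 1 to compound 2, though the place differs: here the site is para to a large group, whereas before it was ortho to a large group and meta to a trifluoromethyl group. Because the earlier step, a 1.3-fold higher number from compound 1 to compound 2 (0.11 log units; within the scatter), stayed within the scatter, a comparably small step, a 1.2-fold higher number from compound 3 to compound 4 (0.08 log units; within the scatter), is expected here. Compound 4 is therefore estimated in this assay at 18 nM, with a likely range from 9 nM to 36 nM.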

Compound 4, half-maximal effective concentration: 17 nM
Compound 4: the middle estimate sits 1.1-fold (0.02 log units) above what was measured; measured number inside the range.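

In this assay, chloro in place of fluoro on an aromatic carbon, here para to a large group, gave a 1.1-fold higher number from compound 3 to compound 4 (0.05 log units; within the scatter), so on this core too the change left the number essentially where it was. Set beside the step on the core of compound 1, the two results cannot be told apart: the same change on two cores in this assay, a 1.3-fold higher number (0.11 log units; within the scatter) from compound 1 to compound 2 and a 1.1-fold higher number (0.05 log units; within the scatter) from compound 3 to compound 4, 1.1-fold (0.05 log units) apart, within the scatter of two such steps. Within the data shown here, this shows that, for these two pairs, the exchange carried from one core to the other without a detectable difference, but it rests on only two steps at sites that are not the same, and it shows neither that the exchange would stay this small on a further core or at another site nor why it is small.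

On these data alone, it remains open whether an amine, a nitrile or a methoxy group in place of the halogen would leave the number as little changed on either core. Also open, as far as these compounds go, is what the bromo group of compound 3 and compound 4 contributes to their numbers.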